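The compounds below may be only part of what the source reports. "The series", "measured", "known", "first", "only" and "open" are said of these compounds alone.

Measured compounds in an in vitro functional assay on HEK285-7 cells for antagonist activity at prostaglandin D2 receptor 2 (Homo sapiens), read by BRET and beta-arrestin recruitment; on this read-out lower numbers stand for stronger inhibition and higher numbers for weaker inhibition:
- compound 1, `Cc1nc(-c2ccc(Cl)cc2)c(CC(=O)O)s1`: 41000 nM
- compound 2, `CCC(c1ccccc1)c1nc(-c2ccc(Cl)cc2)c(CC(=O)O)s1`: > 100000 nM
- compound 3, `O=C(O)Cc1sc(CSc2ccccc2)nc1-c1ccc(Cl)cc1`: 450 nM

Compound 2 gives only a limit in this assay, (the limit of > 100000 nM in this assay, at which 1 of the 3 values shown sits); no number is known for it, so it stands apart from compound 1 and compound 3, both of which return numbers. Compound 4, `O=C(O)Cc1sc(C(c2ccccc2)c2ccc(Cl)cc2)nc1-c1ccc(Cl)cc1`, differs from compound 2 in one place: 4-chlorophenyl in place of ethyl on a saturated chain carbon bound to two aromatic carbons.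

Within the data shown here, no measured step covers this exact change. Among the measured compounds shown here, the one measured step at a related position is a 91-fold lower number from compound 1 to compound 3 (1.96 log units; beyond the scatter), where a group carrying an aromatic ring entered on a saturated chain carbon bound to an aromatic carbon. That step was large and in the direction of stronger inhibition. Compound 4 likewise places an aromatic ring on the chain carbon, and the ethyl of compound 2 leaves. Since compound 2 sits at a limit, only a rough direction can be read across, and a gain beyond the scatter is expected.

Compound 4 is therefore estimated at 8000 nM in this assay, with a range of 1000 nM to 60000 nM, which means an expected step of an at least 12-fold lower number from compound 2 to compound 4 (1.09 log units; beyond the scatter).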

Compound 4, half-maximal inhibitory concentration: 75 nM
Estimate against measurement, compound 4: 110-fold (2.03 log units) above; measured number below the stated range.
By their numbers in this assay, from the lowest: compound 4; then compound 3; then compound 1. At a limit, above all of these: compound 2.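

In this assay, the identity of the second group on the saturated chain carbon bound to two aromatic carbons decides the outcome, with the phenyl on that carbon unchanged: an at least 1300-fold lower number from compound 2 to compound 4 (3.12 log units; beyond the scatter). Compound 2 gives only a limit and no number: the limit of > 100000 nM in this assay, at which 1 of the 4 values shown sits. The earlier compounds shown here showed a gain from adding a group on a chain carbon, whereas this pair shows that a carbon bearing two groups can return a measurable number in the nanomolar range only with some groups, so ethyl and 4-chlorophenyl are not interchangeable here.

As far as these compounds go, it remains open whether the chlorine of the 4-chlorophenyl contributes to this gain, or whether a cyclohexyl or a pyridine ring would serve on this carbon. From the compounds shown here alone, the effect of an amine or a longer chain at this position also remains open.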